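Chloro in place of hydroxy in compound 2

The source may hold more compounds than are shown below. What is called first, only, known or untested is meant among the compounds shown, and "the series" means these compounds.

Values so far in a functional assay on L1210 cells (Mus musculus) for inhibition (a lower number here means a stronger inhibitor, a higher number a weaker inhibitor), for three compounds:
compound 1 `Nc1ccn(C/C=C/CCl)c(=O)n1` reads 50000 nM in this series
compound 2 `Nc1ccn(C/C=C/CO)c(=O)n1` reads > 550000 nM (a limit)
compound 3 `Nc1nc(O)c2ncn(C/C=C\CO)c2n1` reads 680000 nM on a different core

Compound 2 reads > 550000 nM as a limit of the assay and not a number. The data thus hold the limit of > 550000 nM in this assay, at which 1 of the 3 values shown sits, and the step starts from that limit.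

Compound 4 `Nc1ccn(C/C=C\CCl)c(=O)n1` brings the change 3-chloroprop-1-en-1-yl in place of 3-hydroxyprop-1-en-1-yl on a saturated chain carbon bound to an aromatic nitrogen and so has 3-chloroprop-1-en-1-yl in place of 3-hydroxyprop-1-en-1-yl on a saturated chain carbon bound to an aromatic nitrogen. Within the data shown here, one measured step bears on this, the same exchange run in reverse. That step, an at least 11-fold higher number from compound 1 to compound 2 (1.04 log units; beyond the scatter) and hydroxy in place of chloro, is large and beyond the scatter. Among the measured compounds shown here, compound 3 has no chloro partner and adds no step. A large move to a lower number is therefore expected in this assay for the return exchange. The expected step is an at least 11-fold lower number from compound 2 to compound 4 (1.04 log units; beyond the scatter). Compound 4 is estimated at 50000 nM with 15000 nM to 200000 nM as the expected range.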

Compound 4, half-maximal inhibitory concentration: 10000 nM
Compound 4: middle estimate off by 5.0-fold (0.70 log units), on the high side, and the stated range ends above it.
By their numbers in this assay, from the lowest: compound 4; then compound 1; then compound 3.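

The exchange of 3-hydroxyprop-1-en-1-yl for 3-chloroprop-1-en-1-yl gives an at least 55-fold lower number from compound 2 to compound 4 (1.74 log units; beyond the scatter) in this assay, and the size of this step rests on a limit: the limit of > 550000 nM in this assay, at which 1 of the 4 values shown sits.

The earlier compounds shown here did not show that the configuration of the double bond also counts at this place, with a 5.0-fold lower number from compound 1 to compound 4 (0.70 log units; beyond the scatter), so the Z-drawn compound is the stronger inhibitor of this pair. Nothing else separates the two compounds, so this gap can be set on configuration alone: the fact that compounds 1 and 4 differ only in the configuration as drawn

The compounds shown leave open how a hydroxy compound responds to the same change of configuration, as compound 2 is only a limit and compound 3 has a different core. They also leave open whether an amine or a bromine atom in place of chloro would read like compound 4.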